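The source may report more compounds than this note shows. Statements on the series, on what has been measured and on what is new or still open speak of the compounds shown alone.

Of the compounds shown here, two that share one core have been tested so far. Compound 1 `N#Cc1ccc(Nc2nc(Oc3ccnc4ccccc34)nc(N3CCN(C(c4ccccc4)c4ccc(Cl)cc4)CC3)n2)cc1C(F)(F)F` and compound 2 `CC(C)N1CCN(c2nc(Nc3ccc(C#N)c(C(F)(F)F)c3)nc(Oc3ccnc4ccccc34)n2)CC1` were both run in a functional assay on DU-145 cells (Homo sapiens) for cytotoxicity, read by sulforhodamine B assay, with a stated time of 48 h; on this read-out lower numbers stand for stronger inhibition of growth and higher numbers for weaker inhibition of growth. For compound 1 the assay gives only a limit, > 100000 nM. For compound 2 the assay likewise gives only a limit, > 100000 nM. Compound 2 therefore stands at the limit of > 100000 nM in this assay, at which 2 of the 2 values shown sit, with no number of its own.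

Compound 3 `N#Cc1ccc(Nc2nc(Oc3ccnc4ccccc34)nc(N3CCN(Cc4ccccc4)CC3)n2)cc1C(F)(F)F` has not been measured in this assay yet. It differs from compound 2 by benzyl in place of isopropyl on an amine nitrogen in a ring. Going by the values given here, no measured step covers this change, so compound 3 is expected to remain near the limit, with the step from compound 2 to compound 3 estimated as a step that the limit leaves unreadable from compound 2 to compound 3. Compound 3 is thus expected at 150000 nM, within a range from 40000 nM to 500000 nM.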

Compound 3, concentration for total growth inhibition: > 100000 nM
Compound 3: no number, only a limit; the forecaster's own chance of this, stated with the estimate: 75%; the middle value is on the limit's open side.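

Going by these compounds alone, compound 1, compound 2 and compound 3 each give only a limit, so no step between them can be read: the limit of > 100000 nM in this assay, at which 3 of the 3 values shown sit. The compounds shown leave open whether any of these groups on the amine nitrogen changes growth inhibition at all.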